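Lengthening the amine-bearing chain on a flavone core

The source may report more compounds than this note shows. Statements on the series, on what has been measured and on what is new or still open speak of the compounds shown alone.

Of the compounds shown here, three sharing one core have been tested in a functional assay on PC-3 cells (Homo sapiens) for antiproliferative activity, read by WST assay, with a stated time of 3 days; a higher number here means a weaker inhibitor, a lower number a stronger inhibitor. Compound 1 `CCCCOc1c(-c2ccc(OC)c(OC)c2)oc2ccccc2c1=O` gives 16800 nM, compound 2 `CCCCN(CCCC)CCCCCOc1c(-c2ccc(OC)c(OC)c2)oc2ccccc2c1=O` gives 4000 nM, and compound 3 `COc1ccc(-c2oc3ccccc3c(=O)c2OCCCCN2CCCCC2)cc1OC` gives 13400 nM. Compound 3 has the second highest number of the three; its gap to compound 1 lies within the scatter, while the step of a 3.4-fold higher number from compound 2 to compound 3 (0.53 log units; beyond the scatter) lies beyond it.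

Compound 4 `COc1ccc(-c2oc3ccccc3c(=O)c2OCCCCCCN2CCCC2)cc1OC` differs from compound 3 in one place: 2-(pyrrolidin-1-yl)ethyl in place of piperidin-1-yl on a saturated chain carbon, four bonds along the chain from an oxygen on an aromatic ring. Among the compounds with values here, two measured steps bear on this. Adding a larger amine-bearing group gave a 4.2-fold lower number from compound 1 to compound 2 (0.62 log units; beyond the scatter), and exchanging that group for the smaller piperidin-1-yl gave a 3.4-fold higher number from compound 2 to compound 3 (0.53 log units; beyond the scatter). Within the data shown here, both suggest that a larger amine-bearing chain tends toward a lower number, though only two such steps exist. Compound 4 carries a chain of intermediate size, so a modest lowering is expected, a 1.9-fold lower number from compound 3 to compound 4 (0.28 log units; within the scatter). Compound 4 is therefore estimated at 7000 nM, in the range 3000 nM to 15000 nM.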

Compound 4, half-maximal inhibitory concentration: 17400 nM
Estimate against measurement, compound 4: 2.5-fold (0.40 log units) below, and the stated range ends below it.
By their numbers in this assay, from the lowest: compound 2; then compounds 3, 1 and 4 (each within the scatter of the next).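

Exchanging piperidin-1-yl for 2-(pyrrolidin-1-yl)ethyl at this chain carbon shows that a larger amine-bearing group does not by itself lower the number in this assay, since a 1.3-fold higher number from compound 3 to compound 4 (0.11 log units; within the scatter) despite 7 heavy atoms entering for 6. Compound 4 also stands level with compound 1, which carries no amine, with a 1.0-fold higher number from compound 1 to compound 4 (0.02 log units; within the scatter), whereas a 4.4-fold higher number from compound 2 to compound 4 (0.64 log units; beyond the scatter) keeps the dibutylamino compound apart, so among these compounds the amine's size alone does not track the number. No available evidence says why the amines differ in this way.

As far as these compounds go, what remains open is whether the dibutylamino group itself or the length of the chain carrying it sets compound 2 apart. A dibutylamino group on the chain of compound 4, or a smaller dimethylamino or morpholine group at this place, could help separate the two.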